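Series notes: from compound 2 to compound 3

A few compounds are considered here, and "the series" means these few. Any claim that something is new, unique, unknown or untested is made for them only; others in the source may bear on it.

Of the compounds shown here, two have been read in a functional assay on AML cells (Homo sapiens) for antiproliferative activity, read by MTT assay, with a stated time of 48 h (a lower number here means a stronger inhibitor, a higher number a weaker inhibitor), so far. Compound 1 (`O=C(O)/C=C/c1ccc(-c2ccc(F)cc2)c(Cl)c1`) gives > 5000 nM as a limit of the assay. Compound 2 (`CC(C)(C)C#Cc1cc(-c2ccc(/C=C/C(=O)O)cc2Cl)ccc1O`) gives > 5000 nM as a limit of the assay too, so it has no number of its own. Neither compound has yet given a number (the limit of > 5000 nM in this assay, at which 2 of the 2 values shown sit).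

Compound 3 (`Cc1cccc(C)c1-c1cc(-c2ccc(/C=C/C(=O)O)cc2Cl)ccc1O`) remains unmeasured. It carries 2,6-dimethylphenyl in place of 3,3-dimethylbut-1-yn-1-yl on an aromatic carbon, ortho to a hydroxy group (2,6-dimethylphenyl in place of 3,3-dimethylbut-1-yn-1-yl on an aromatic carbon). Going by the values given here, no measured step is available to size this change, so no step beyond the scatter is expected in this assay for now. As an estimate, a number no higher from compound 2 to compound 3 (the limit leaves the size open) is what is expected here. Compound 3 is estimated at 5000 nM with an expected range from 1800 nM to 14000 nM in this reading.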

Compound 3, half-maximal inhibitory concentration: > 5000 nM
Compound 3: a limit, no number; the forecaster's own chance of this, stated with the estimate: 60%; the middle value sits exactly at the limit.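

In this assay, going by these compounds alone, compound 3 gives > 5000 nM, a limit and not a number; with compound 2 also at a limit, no step between the two can be read. The compounds shown leave open what change to the shared core would give a measurable number: the limit of > 5000 nM in this assay, at which 3 of the 3 values shown sit.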